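The compounds below may be only part of what the source reports. "The series", "measured", "known", "first", "only" and "open" are said of these compounds alone.

Working notes on the series. Going by the values given here, in a functional assay (786-0 cells, Homo sapiens) for inhibition, read by sulforhodamine B assay, with a stated time of 48 h (a higher number here means a weaker inhibitor of growth, a lower number a stronger inhibitor of growth), compound 2 `O=C(Cc1csc2nc(-c3ccc(Br)cc3)cn12)N/N=C/c1ccccc1O` gives 17800 nM, the only actual number available so far. Compound 1 `O=C(Cc1csc2nc(-c3ccc(Br)cc3)cn12)N/N=C/c1ccccc1` reads > 100000 nM, which is a limit of the assay and not a number.

Compound 3 `O=C(Cc1csc2nc(-c3ccc(Br)cc3)cn12)N/N=C/c1ccc(O)cc1` has the same atoms as compound 2, joined differently: 4-hydroxyphenyl in place of 2-hydroxyphenyl on a carbon with a double bond to nitrogen. The change is 4-hydroxyphenyl in place of 2-hydroxyphenyl on a carbon with a double bond to nitrogen.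

Among the compounds with values here, only one measured step bears on this, namely an at least 5.6-fold lower number from compound 1 to compound 2 (0.74 log units; beyond the scatter), and it starts from a limit. That step shows what adding a hydroxy does, not what moving one does, so it sets only a rough scale. Compound 3 keeps a hydroxy, so part of that gain is expected to remain. In this assay a modest shift towards a higher number is therefore expected, though a step within the scatter would not be surprising. The expected change is a 1.7-fold higher number from compound 2 to compound 3 (0.23 log units; within the scatter). For compound 3 the estimated value is 30000 nM, with an expected range from 10000 nM to 90000 nM.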

Compound 3, concentration for total growth inhibition: 89100 nM
The estimate for compound 3 lay 3.0-fold (0.47 log units) below the measured number, within the range that was stated.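

In this assay, the place of the hydroxy on the ring matters as well as its presence: 4-hydroxyphenyl in place of 2-hydroxyphenyl gives a 5.0-fold higher number from compound 2 to compound 3 (0.70 log units; beyond the scatter), a step beyond the scatter that the earlier pair could not show. The gain seen on adding a hydroxy therefore holds for 2-hydroxyphenyl, as in an at least 5.6-fold lower number from compound 1 to compound 2 (0.74 log units; beyond the scatter), but is not shown for 4-hydroxyphenyl, where the step is an at least 1.1-fold lower number from compound 1 to compound 3 (0.05 log units; that floor lies within the scatter). The value of compound 1 is a limit and not a number, so this last step gives a floor only and does not separate compound 3 from compound 1: the limit of > 100000 nM in this assay, at which 1 of the 3 values shown sits.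

The compounds shown leave open whether the hydroxy of 2-hydroxyphenyl is itself needed, or whether a methoxy, an amine or a fluorine in its place would give a number like that of compound 2. Also open, from the compounds shown here alone, is whether the difference between 2-hydroxyphenyl and 4-hydroxyphenyl persists when the bromine on the shared core is replaced by chlorine or a methyl group.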